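The source may hold more compounds than are shown below. What is called first, only, known or untested is meant among the compounds shown, and "the series" means these compounds.

In a functional assay on PC-3 cells (Homo sapiens) (a higher number here means a weaker inhibitor of growth, a lower number a stronger inhibitor of growth), three compounds have been measured. Compound 1 `O=S(=O)(/C=C/c1ccc(F)cc1F)Cc1ccc(Nc2ncnc3ccccc23)cc1` gives > 100000 nM, which is a limit of the assay and not a number. Compound 2 `O=S(=O)(/C=C/c1ccc(C(F)(F)F)cc1F)Cc1ccc(Nc2ncnc3ccccc23)cc1` gives 100000 nM. Compound 3 `COc1cc2ncnc(Nc3ccc(CS(=O)(=O)/C=C/c4ccc(Cl)cc4Cl)cc3)c2cc1OC`, which has a core different from the other two, gives 5000 nM. Its number is the lower of the two actual numbers, and its gap to compound 2 lies beyond the scatter.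

Compound 4 `COc1cc2ncnc(Nc3ccc(CS(=O)(=O)/C=C/c4ccc(Br)cc4)cc3)c2cc1OC` keeps the core of compound 3 and changes the group on the double-bonded chain carbon: 4-bromophenyl in place of 2,4-dichlorophenyl on a double-bonded chain carbon bound to a double-bonded chain carbon. Within the data shown here, only one measured step touches a group in this region, a number no higher from compound 1 to compound 2 (the limit leaves the size open). On these data alone, the size of that step stays open because of the limit of > 100000 nM in this assay, at which 1 of the 3 values shown sits. Among the measured compounds shown here, it was also taken on the other core, and no measured step replaces the 2,4-dichlorophenyl group itself. The data therefore offer no size to carry over, and no step beyond the scatter is expected in this assay, in either direction. The expectation rests on compound 3 at 5000 nM, and it remains uncertain. The expected change is no change at the digits printed from compound 3 to compound 4 (within the scatter). Compound 4 is estimated at 5000 nM, with an expected range of 1200 nM to 25000 nM.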

Compound 4, concentration for 50% growth inhibition: 9500 nM
Compound 4: middle estimate off by 1.9-fold (0.28 log units), on the low side; measured number inside the range.
By their numbers in this assay, from the lowest: compounds 3 and 4 (each within the scatter of the next); then compound 2.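

In this assay, 4-bromophenyl in place of 2,4-dichlorophenyl on a double-bonded chain carbon bound to a double-bonded chain carbon gives a 1.9-fold higher number from compound 3 to compound 4 (0.28 log units; within the scatter). Among these compounds, this is the first step with a readable size that touches this position, and it shows that on the core of compound 3, this ring can exchange its chlorine atoms for a bromine without a step beyond the scatter. The only earlier step touching a group in this region, taken on the other core, cannot be read: the limit of > 100000 nM in this assay, at which 1 of the 4 values shown sits.

Since the two chlorine atoms leave and the bromine enters in a single step, the compounds shown do not separate what each halogen contributes, and they leave open whether plain phenyl would also stay within the scatter of compound 3. Also open, on these data alone, is whether a ring carrying an amine or a carboxylic acid would hold its number in this assay on this core, and whether 4-bromophenyl would give a readable number on the core of compound 1.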